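Notes on the step from compound 2 to compound 3

The compounds below may be only part of what the source reports. "The series", "measured", "known", "first", "only" and "open" are said of these compounds alone.

Compound 1 (`O=C(NC[C@@H]1[C@H]2CN(C(=O)C3CC3c3cc(Cl)cc(Cl)c3)C[C@@H]12)c1ccc2[nH]c(=O)oc2c1`) : < 1 ug/mL (a limit)
Compound 2 (`CC(OC(=O)N1C[C@@H]2[C@@H](CNC(=O)c3ccc4[nH]c(=O)oc4c3)[C@@H]2C1)c1cc(Cl)cc(Cl)c1`) : < 1 ug/mL (a limit)

Both compounds were run in a physicochemical assay for solubility, with a stated time of 24 h, at pH 6.8; a lower number here means a less soluble compound, a higher number a more soluble compound. Compound 1 gives < 1 ug/mL, which is a limit and not a number. Compound 2 gives < 1 ug/mL, which is also a limit and not a number. Compound 2 therefore has no number of its own and stands with compound 1 at the limit of < 1 ug/mL in this assay, at which 2 of the 2 values shown sit.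

Compound 3 (`Cc1ccc(COC(=O)N2C[C@@H]3[C@@H](CNC(=O)c4ccc5[nH]c(=O)oc5c4)[C@@H]3C2)nc1`) differs from compound 2 by a group of 8 heavy atoms (7 carbon, 1 nitrogen; one six-membered aromatic ring with 1 hetero atom) in place of a group of 10 heavy atoms (8 carbon, 2 chlorine; one six-membered aromatic ring of carbon only), on an oxygen next to a carbonyl group. The entering group is (5-methylpyridin-2-yl)methyl, on an oxygen next to a carbonyl group.

Among the measured compounds shown here, the only measured step is a step that the two limits leave unreadable from compound 1 to compound 2. It changes a different group, on a carbonyl carbon, and offers no size to carry over. The expectation in this assay therefore rests on the structural change alone and is loosely held. A modest rise is expected, and compound 3 may still report only a limit. The expected step is an at least 4.0-fold higher number from compound 2 to compound 3 (0.60 log units; beyond the scatter). For compound 3 the estimated value is 4 ug/mL, with an expected range from 1 ug/mL to 25 ug/mL.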

Compound 3, solubility: 56 ug/mL
The estimate for compound 3 lay 14-fold (1.15 log units) below the measured number, outside the stated range (above it).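

In this assay, the exchange on an oxygen next to a carbonyl group gives the only true number among the compounds shown, while the other two report only a limit: the limit of < 1 ug/mL in this assay, at which 2 of the 3 values shown sit. On these data alone, with (5-methylpyridin-2-yl)methyl in place of the group of 10 heavy atoms that carries the chlorine pair, the result is an at least 56-fold higher number from compound 2 to compound 3 (1.74 log units; beyond the scatter), so this position can carry a large shift in the read-out, and the true size of that shift remains unknown because one end of the step is a limit. The wider exchange on a carbonyl carbon gives an at least 56-fold higher number from compound 1 to compound 3 (1.74 log units; beyond the scatter), which removes the three-membered ring as well and has the same limit at its lower end, while the step from compound 1 to compound 2 cannot be read.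

The data do not separate the loss of the two chlorine atoms from the gain of the ring nitrogen or the methyl group, and they give no cause for the step. A plain benzyl group on the same oxygen, with neither chlorine nor ring nitrogen, would help to pull these contributions apart.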